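Shortening the side chain in a second core

This account rests on a few compounds, and the source may have more. Where it says the series, first, only, none or still open, it means among the compounds named here.

In a functional assay, read by spectrophotometry, with a stated time of 6 min (on this read-out lower numbers stand for an effect already at smaller amounts and higher numbers for an effect only at larger amounts of compound), compound 1 `COc1c(C)cc(O)cc1/C=C/C(C)(O)CC(=O)/C=C(/C)CCCC(C)C(=O)/C=C/C(C)(C)O` gives 22500 nM. Compound 2 `COc1c(C)cc(O)cc1/C=C/C(C)(O)CC(=O)/C=C(/C)CCCC(C)=O` differs from it by one change, (acetyl in place of 1-((3-hydroxy-3-methylbut-1-en-1-yl)carbonyl)ethyl on a saturated chain carbon, three bonds along the chain from a double-bonded chain carbon), and in this assay compound 2 gives 55900 nM, so that a 2.5-fold higher number from compound 1 to compound 2 (0.40 log units; beyond the scatter). Compound 3 `COc1c(C)cc(O)cc1C/C=C(\C)CC(=O)/C=C(/C)CCCC(C)C(=O)/C=C/C(C)(C)O` carries a different core; the difference between the two cores is not broken down here. In this assay compound 3 gives 26300 nM, which lies within the scatter of the value of compound 1 and is lower than that of compound 2 by more than the scatter.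

Compound 4 `COc1c(C)cc(O)cc1C/C=C(\C)CC(=O)/C=C(/C)CCCC(C)=O` is not yet measured. It differs from compound 3 by acetyl in place of 1-((3-hydroxy-3-methylbut-1-en-1-yl)carbonyl)ethyl on a saturated chain carbon, three bonds along the chain from a double-bonded chain carbon, the same change at the same place that separates compound 1 from compound 2. Among the measured compounds shown here, since that earlier change gave a modest rise beyond the scatter, a step of similar size is expected here, a 2.5-fold higher number from compound 3 to compound 4 (0.40 log units; beyond the scatter), because the only measured instance of the change is a 2.5-fold higher number from compound 1 to compound 2 (0.40 log units; beyond the scatter) and compound 3 starts near compound 1. Compound 4 is therefore estimated at 66000 nM in this assay, with a likely range from 35000 nM to 130000 nM.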

Compound 4, half-maximal effective concentration: 51600 nM
The estimate for compound 4 lay 1.3-fold (0.11 log units) above the measured number; the range from low to high includes it.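

In this assay, acetyl in place of 1-((3-hydroxy-3-methylbut-1-en-1-yl)carbonyl)ethyl on the core of compound 3 gives a 2.0-fold higher number from compound 3 to compound 4 (0.29 log units; within the scatter), a step that on its own cannot be separated from the scatter. Set beside the step on the core of compound 1, the exchange reads the same on both cores within the scatter: the same change on two cores in this assay, a 2.5-fold higher number (0.40 log units; beyond the scatter) from compound 1 to compound 2 and a 2.0-fold higher number (0.29 log units; within the scatter) from compound 3 to compound 4, 1.3-fold (0.10 log units) apart, within the scatter of two such steps. With a single pair on each core in a single assay, this shows that the two steps cannot be told apart in size, but it does not show that the exchange would read the same on any further core.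

The compounds shown leave open which part of the larger group accounts for the step, since they offer only that whole group and acetyl. They also leave open how a carboxylic acid, an amine or a longer chain on the same saturated chain carbon would read in this assay, and whether the two cores would still match with those groups.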